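Trading a Carboxylic Acid for a Hydroxamic Acid

A few compounds are considered here, and "the series" means these few. Any claim that something is new, unique, unknown or untested is made for them only; others in the source may bear on it.

Compound 2 `CC(CC(=O)O)c1ccc(NCc2cccc(Oc3ccccc3)c2)cc1` is the starting point. In a functional assay on CHO cells for agonist activity at Free fatty acid receptor 1 (Homo sapiens) (on this read-out lower numbers stand for an effect already at smaller amounts and higher numbers for an effect only at larger amounts of compound), compound 2 gives 126 nM. Of the two numbers shown, the other belongs to compound 3 `Cc1nc(-c2ccc(C(F)(F)F)cc2)sc1CNc1ccc(CCC(=O)NC(C)C)cc1`, which in this assay gives 100 nM, a value within the usual scatter of that of compound 2, so the two are treated as alike. Compound 1 `Cc1nc(-c2ccc(C(F)(F)F)cc2)sc1CNc1ccc(C(=O)O)cc1` gives only a limit in this assay, < 10000 nM. For the measured compounds named here, the single comparable step, a step that the limit leaves unreadable from compound 1 to compound 3, cannot be read in size due to the limit of < 10000 nM in this assay, at which 1 of the 3 values shown sits.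

Compound 4 `O=C(NO)[C@H]1C[C@@H]1c1ccc(NCc2cccc(Oc3ccccc3)c2)cc1` is the untested partner of compound 2. The change is 2-(hydroxycarbamoyl)cyclopropyl in place of 1-(carboxymethyl)ethyl on an aromatic carbon. Going by the values given here, no measured step in this set involves the acid end of the molecule in the same way, so there is no direct precedent for this change. Compound 4 is therefore expected to remain broadly in the range of compound 2, with some loss considered plausible, and the step from a 2.8-fold higher number from compound 2 to compound 4 (0.44 log units; beyond the scatter) is the estimate. Compound 4 is expected to give about 350 nM, with a likely span from 60 nM to 2500 nM.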

Compound 4, half-maximal effective concentration: 14.8 nM
Compound 4: the middle estimate sits 24-fold (1.37 log units) above what was measured, outside the stated range (below it).
By their numbers in this assay, from the lowest: compound 4; then compounds 3 and 2 (each within the scatter of the next).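

In this assay, for the compounds shown here, the exchange of 1-(carboxymethyl)ethyl for 2-(hydroxycarbamoyl)cyclopropyl on an aromatic carbon, para to a large group, gives an 8.5-fold lower number from compound 2 to compound 4 (0.93 log units; beyond the scatter) and is the only readable step in this set. Compound 4 carries no carboxylic acid at all, and on this shared core that exchange brings a gain rather than a loss. The change does two things at once, replacing the open chain with a three-membered ring and the acid with a hydroxycarbamoyl group, and it also brings 2 defined stereocentres.

As far as these compounds go, a carboxylic acid on the cyclopropyl ring, or the hydroxycarbamoyl group on the open chain, would separate these two parts of the change, and the mirror-image form of the ring remains open as well. Nothing shown here explains the size of this step.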